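Sulfonyl pyridone series: liver microsome stability notes

The source may report more compounds than this note shows. Statements on the series, on what has been measured and on what is new or still open speak of the compounds shown alone.

Measured so far:
compound 1 `CCCCc1nc(=O)c(S(=O)(=O)c2ccc(-c3ccc(F)nc3)cc2)c(O)n1-c1c(OC)cccc1OC` — 69%
compound 2 `CCCCc1[nH]c(=O)c(S(=O)(=O)c2ccc(-c3ccncc3C)cc2)c(O)c1-c1c(OC)cccc1OC` — 39%

In an ADME assay on microsomes from liver (Mus musculus) for metabolic stability, using NADPH, with a stated time of 10 min (a higher number here means that more of the compound is left, a lower number that less of the compound is left), compound 1 gives 69% and compound 2 gives 39%; compound 2 thus holds the lower of the two numbers, and the gap to compound 1 lies beyond the scatter. Going by the values given here, no single-point step between measured compounds exists here.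

Compound 3 `CCCCc1[nH]c(=O)c(S(=O)(=O)c2ccc(-n3cc(Cl)ccc3=O)cc2)c(O)c1-c1c(OC)cccc1OC` differs from compound 2 by a group of 8 heavy atoms (5 carbon, 1 nitrogen, 1 oxygen, 1 chlorine; one six-membered aromatic ring with 1 hetero atom) in place of a group of 7 heavy atoms (6 carbon, 1 nitrogen; one six-membered aromatic ring with 1 hetero atom), on an aromatic carbon. With no comparable change measured, no step beyond the scatter is expected in this assay. Compound 3 is estimated at 45%, range 25% to 65%, meaning an expected step of a number 6 percentage points higher from compound 2 to compound 3 (within the scatter).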

Compound 3, percent of the compound remaining: 64%
Compound 3: middle estimate off by 19 percentage points, on the low side; low and high end bracket the measured number.
By their numbers in this assay, from the lowest: compound 2; then compounds 3 and 1 (each within the scatter of the next).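

In this assay, going by these compounds alone, swapping the group on the aromatic carbon, para to a large group, gives a number 25 percentage points higher from compound 2 to compound 3 (beyond the scatter) as the first one-place comparison. The read-out at this position therefore responds to the ring attached there, and 3-methylpyridin-4-yl is not the better of the two groups compared. No measurement available bears on what lies behind this step.

The compounds shown do not separate the contribution of the chlorine from that of the ring carrying it. As far as these compounds go, how an amine or a carboxylic acid at this position would read remains open.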